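Long chain on the weaker configuration: compound 4

The compounds below may be only part of what the source reports. "The series", "measured", "known", "first", "only" and "open" are said of these compounds alone.

In a functional assay on EC9706 cells (Homo sapiens) for antiproliferative activity, read by MTT assay, with a stated time of 48 h (on this read-out higher numbers stand for weaker inhibition and lower numbers for stronger inhibition), compound 1 `CCCCCCCCn1cc(COC[C@@H]2OC[C@H](N)[C@@H]2O)nn1` gives 44300 nM and compound 2 `CCCCCCCCCCCCn1cc(COC[C@@H]2OC[C@H](N)[C@@H]2O)nn1` gives 16000 nM. Compound 3 `CCCCCCCCn1cc(COC[C@@H]2OC[C@H](N)[C@H]2O)nn1` stands at > 128000 nM, which is a limit and not a number. The configuration step reads an at least 2.8-fold higher number from compound 1 to compound 3 (0.46 log units; beyond the scatter), and it goes with the fact that compounds 1 and 3 differ only in the configuration as drawn. Compound 4 `CCCCCCCCCCCCCCCCCCn1cc(COC[C@@H]2OC[C@H](N)[C@H]2O)nn1` carries decyl in place of hydrogen on a saturated chain carbon, eight bonds along the chain from an aromatic nitrogen. Among the measured compounds shown here, the nearest precedent is the chain step in the other configuration, with butyl rather than decyl: a 2.8-fold lower number from compound 1 to compound 2 (0.44 log units; beyond the scatter). For the measured compounds named here, how far it carries over is open, as only that one chain step exists and compound 3 offers only a limit. The expected change in this assay is a move towards a lower number, estimated as an at least 3.6-fold lower number from compound 3 to compound 4 (0.56 log units; beyond the scatter). Compound 4 is expected at about 35000 nM, with an estimated range of 9000 nM to 128000 nM.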

Compound 4, half-maximal inhibitory concentration: 2290 nM
Compound 4: the middle estimate sits 15-fold (1.18 log units) above what was measured, outside the stated range (below it).
By their numbers in this assay, from the lowest: compound 4; then compound 2; then compound 1. At a limit, above all of these: compound 3.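

In this assay, decyl at this saturated chain carbon brings the weaker configuration to a measurable value, with an at least 55-fold lower number from compound 3 to compound 4 (1.74 log units; beyond the scatter). Compound 3 gives > 128000 nM, which is a limit, so the full size of that step stays unfixed. With a 2.8-fold lower number from compound 1 to compound 2 (0.44 log units; beyond the scatter), for butyl in the other configuration, a chain step towards lower numbers now appears in both configurations, although group and configuration both differ between the two steps.

Open, going by these compounds, are how decyl reads on the configuration of compound 1 and how a longer chain or a carboxylic acid in place of decyl would read.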